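Swapping a piperazine for chlorine on a shared pyrimidine core

The source may report more compounds than this note shows. Statements on the series, on what has been measured and on what is new or still open speak of the compounds shown alone.

Measured so far:
- compound 1, `Cc1cc(NCCCCCCNc2ccnc3cc(Cl)ccc23)nc(N2CCN(C)CC2)n1`: 10400 nM
- compound 2, `Cc1cc(NCCNc2ccnc3cc(Cl)ccc23)nc(N2CCCCC2)n1`: "not determined" (no result reported)

For the measured compounds named here, compound 1 is the only compound in this set with a number in an ADME assay on Vero cells (Chlorocebus sabaeus) for cytotoxicity, read by neutral red uptake, with a stated time of 48 h; on this read-out higher numbers stand for weaker inhibition and lower numbers for stronger inhibition; compound 2 was run in the same setting, but for compound 2 the entry reads "not determined" (no result reported), so nothing can be said about how the two compare. Compound 1 therefore stands alone as the reference point for this assay.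

Compound 3, `Cc1cc(NCCCCCCNc2ccnc3cc(Cl)ccc23)nc(Cl)n1`, has not yet been measured. It differs from compound 1 in a single place: chloro in place of 4-methylpiperazin-1-yl on an aromatic carbon. The chain of six carbons, the methyl group and the rest of the shared core stay exactly as in compound 1.

Going by the values given here, with no measured pair to draw on, the size of this step is a guess. The shown value of compound 1 in this assay gives only a starting point; the change itself gives no direction that can be read from other compounds here. Compound 3 is expected to land near compound 1, with the step of a 1.5-fold lower number from compound 1 to compound 3 (0.17 log units; within the scatter) treated as uncertain in either direction. The estimated value for compound 3 is 7000 nM, with a range from 2000 nM to 25000 nM.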

Compound 3, half-maximal inhibitory concentration: 32700 nM
Beside the measured number, compound 3's estimate is 4.7-fold (0.67 log units) below it, outside the stated range (above it).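

In this assay, for the compounds shown here, exchanging the 4-methylpiperazin-1-yl group on an aromatic carbon between two ring nitrogen atoms for chloro gives a 3.1-fold higher number from compound 1 to compound 3 (0.50 log units; beyond the scatter), so this is the first sign that the group at this place affects the read-out. The direction is toward weaker inhibition, which means that the larger group with its non-aromatic ring is not needed for activity in this cell assay and that the much smaller chloro gives the higher number of the pair, with the chain of six carbons and the methyl group unchanged. The data offer no measured explanation for this change.

A single pair cannot separate the effect of losing the 4-methylpiperazin-1-yl group from the effect of gaining chloro, and it cannot show whether the values follow any trend in group size. A simple amine or a morpholine ring at the same place would help to settle this, while a longer chain with each of these two groups would test whether the step holds beyond the chain of six carbons.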